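A few compounds are considered here, and "the series" means these few. Any claim that something is new, unique, unknown or untested is made for them only; others in the source may bear on it.

Measured so far:
- compound 1, `Cc1nc(C#Cc2cc(I)cc([N+](=O)[O-])c2)cs1`, giving 1.75 nM in a functional assay on HEK293 cells for antagonist activity at metabotropic glutamate receptor 5 (Rattus norvegicus), read by calcium flux; on this read-out higher numbers stand for weaker inhibition and lower numbers for stronger inhibition
- compound 2, `O=[N+]([O-])c1cc(F)cc(C#Cc2ccccn2)c1`, giving 0.66 nM in this assay

Of these two numbers, compound 2 holds the lower one, and compound 1 stands clearly higher, beyond the usual scatter of repeats. The two structures differ in more than one place, so nothing can be said about which of their differences carries that gap.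

Compound 3, `O=[N+]([O-])c1cc(I)cc(C#Cc2ccccn2)c1`, keeps the whole of compound 2 except for one change: iodo in place of fluoro on an aromatic carbon. The same iodo group also appears in compound 1, but there it sits in a compound whose other arm is different, so compound 1 cannot serve as a direct guide for this single exchange.

Going by the values given here, with no measured pair showing the effect of swapping fluoro for iodo on its own, a small step is expected, if any, and its direction is uncertain. For compound 3 the number in this assay is estimated at 1 nM, with a likely range from 0.4 nM to 2.5 nM. This estimate means a step of a 1.5-fold higher number from compound 2 to compound 3 (0.18 log units; within the scatter), which is expected to stay within the scatter.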

Compound 3, half-maximal inhibitory concentration: 2.09 nM
Compound 3: middle estimate off by 2.1-fold (0.32 log units), on the low side; measured number inside the range.
By their numbers in this assay, from the lowest: compound 2; then compounds 1 and 3 (each within the scatter of the next).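

In this assay, going by these compounds alone, with the pyridin-2-yl arm held fixed, iodo in place of fluoro on this aromatic carbon gives a 3.2-fold higher number from compound 2 to compound 3 (0.50 log units; beyond the scatter), the first reading of this exchange on its own. This modest step beyond the scatter shows that the position accepts either halogen while inhibition remains, with fluoro giving the stronger inhibition of the two. With iodo held fixed, pyridin-2-yl in place of 2-methyl-1,3-thiazol-4-yl on a triple-bonded carbon gives a 1.2-fold higher number from compound 1 to compound 3 (0.08 log units; within the scatter), so these two arms cannot be told apart in this series. Nothing at hand explains why the halogen exchange moves the number.

The compounds shown leave open whether chloro or bromo at this position would fall between fluoro and iodo, and how a methoxy group or an amine would compare there. They also leave open whether fluoro would keep its edge over iodo on the 2-methyl-1,3-thiazol-4-yl arm, since the halogen exchange has been read only with pyridin-2-yl in place.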